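The compounds below may be only part of what the source reports. "The series", "measured", "known", "first", "only" and "open" are said of these compounds alone.

Of the compounds shown here, three built on a shared core have been measured in a functional assay on SK-OV-3 cells (Homo sapiens) for inhibition, read by sulforhodamine B assay, with a stated time of 48 h; on this read-out lower numbers stand for stronger inhibition of growth and higher numbers for weaker inhibition of growth. Compound 1, `COc1ccc(-c2cc(/C=C/C(=O)c3cc(OC)c(OC)c(OC)c3)[nH]n2)cc1OC`, gives 5470 nM. Compound 2, `COc1ccc(C(=O)/C=C/c2cc(-c3cc(OC)c(OC)c(OC)c3)n[nH]2)cc1`, gives 3990 nM in this assay. Compound 3, `COc1ccc(C(=O)/C=C/c2cc(-c3cc(OC)c(OC)c(OC)c3)n[nH]2)cc1OC`, gives 2790 nM in this assay. Compound 3 therefore carries the lowest of the three numbers, yet its gaps to compound 2 and to compound 1 both fall within the scatter of repeated measurements, so none of the three can be called more potent than another.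

Compound 4, `COc1cc(C(=O)/C=C/c2cc(-c3cc(OC)c(OC)c(OC)c3)n[nH]2)cc(OC)c1OC`, has not yet been measured. It differs from compound 3 by methoxy in place of hydrogen on an aromatic carbon. Going by the values given here, only one measured step bears on this change, and it is of the same kind, methoxy in place of hydrogen on an aromatic carbon: a 1.4-fold lower number from compound 2 to compound 3 (0.16 log units; within the scatter). Among the compounds with values here, that step stayed inside the scatter, and it is the only guide available, so the change into compound 4 is not expected to move the number by more than the scatter, with the direction uncertain and, if anything, slightly downward. The step is thus estimated as a 1.2-fold lower number from compound 3 to compound 4 (0.08 log units; within the scatter). For compound 4 the expected value in this assay is 2300 nM, within a range from 900 nM to 6000 nM.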

Compound 4, concentration for 50% growth inhibition: 3200 nM
Compound 4: the middle estimate sits 1.4-fold (0.14 log units) below what was measured; the measured number falls inside the stated range.
By their numbers in this assay, from the lowest: compounds 3, 4, 2 and 1 (each within the scatter of the next).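

In this assay, methoxy in place of hydrogen at this position, on a six-membered aromatic ring of carbon only, ortho to a methoxy group and meta to a large group, gives a 1.1-fold higher number from compound 3 to compound 4 (0.06 log units; within the scatter), so a methoxy is accepted here with no change that can be told from the scatter. The same kind of change also links a second pair of compounds on a different core, giving a 1.7-fold lower number from compound 1 to compound 4 (0.23 log units; within the scatter), and this step too stays within the scatter. Earlier there was a single step of this kind to go on, whereas now a small effect of this change can be seen on two cores: the same change on two cores in this assay, a 1.4-fold lower number (0.16 log units; within the scatter) from compound 2 to compound 3 and a 1.7-fold lower number (0.23 log units; within the scatter) from compound 1 to compound 4, 1.2-fold (0.08 log units) apart, within the scatter of two such steps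

With methoxy the only group shown entering at this position, the compounds leave open how a hydroxyl, an amine, a carboxylic acid or a longer chain such as butoxy would fare there. They also leave open whether any change on this ring can move the number beyond the scatter, since every step shown here stays within it.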